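This account rests on a few compounds, and the source may have more. Where it says the series, first, only, none or still open, it means among the compounds named here.

Values so far in a functional assay on HCT-116 cells (Homo sapiens) for inhibition, read by MTT assay, with a stated time of 48 h; on this read-out higher numbers stand for weaker inhibition and lower numbers for stronger inhibition
- compound 1 `COc1ccc(CNc2cc(OC)c(OC)c(OC)c2)cc1Cl` gives 41700 nM
- compound 2 `C/C=C/C(=O)N(Cc1ccc(OC)c(C)c1)c1cc(OC)c(OC)c(OC)c1` gives 23500 nM
- compound 3 `COc1ccc(CNc2cc(OC)c(OC)c(OC)c2)cc1C` gives 60900 nM

Compound 2 (23500 nM) lies within the scatter of compound 1 (41700 nM). Its gap on the other side is beyond the scatter but modest (a 2.6-fold higher number from compound 2 to compound 3 (0.41 log units; beyond the scatter)), and that step is hydrogen in place of (prop-1-en-1-yl)carbonyl on a nitrogen on an aromatic ring.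

The step under study leads to compound 4 `C/C=C/C(=O)N(Cc1ccc(OC)c(F)c1)c1cc(OC)c(OC)c(OC)c1` and leaves that nitrogen untouched. It is fluoro in place of methyl on an aromatic carbon (fluoro in place of methyl on an aromatic carbon, ortho to a methoxy group).

The nearest measured evidence is methyl in place of chloro on an aromatic carbon (a 1.5-fold higher number from compound 1 to compound 3 (0.16 log units; within the scatter)), which stays within the scatter. Among the compounds with values here, that swap was measured only on compounds without the carbonyl group on nitrogen, and no fluoro compound has been measured yet, so the support is indirect. The step at the nitrogen says nothing direct about this ring change.

No step beyond the scatter is therefore expected in this assay, and no direction is favoured. The expected result is a 1.0-fold higher number from compound 2 to compound 4 (0.01 log units; within the scatter) (an estimate). For compound 4 the estimated value is 24000 nM (expected range 10000 nM to 55000 nM).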

Compound 4, half-maximal inhibitory concentration: 1160 nM
Estimate against measurement, compound 4: 21-fold (1.32 log units) above; measured number below the stated range.
By their numbers in this assay, from the lowest: compound 4; then compounds 2, 1 and 3 (each within the scatter of the next, the first and the last beyond it).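

Working notes on the series: in this assay the aromatic carbon ortho to a methoxy group is clearly sensitive to the group it carries, and with the (prop-1-en-1-yl)carbonyl on nitrogen, fluoro in place of methyl gives a 20-fold lower number from compound 2 to compound 4 (1.31 log units; beyond the scatter) as a large step toward stronger inhibition. Within the data shown here, the only earlier change at this carbon, methyl in place of chloro with hydrogen on that nitrogen, gave a 1.5-fold higher number from compound 1 to compound 3 (0.16 log units; within the scatter) and so showed no sign of a step of this size. The data shown offer no measurement that accounts for the step.

On these data alone, it remains open whether fluoro in place of methyl gives a step of similar size when the nitrogen carries hydrogen, so the dependence of this change on the (prop-1-en-1-yl)carbonyl cannot yet be judged. Also open, as far as these compounds go, is how a trifluoromethyl group or a nitrile at this same carbon would read against the 3-fluoro-4-methoxyphenyl of compound 4 with the rest of the structure held constant.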